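Swapping a chlorophenyl for a trimethoxyphenyl in a growth inhibitor

The source may hold more compounds than are shown below. What is called first, only, known or untested is meant among the compounds shown, and "the series" means these compounds.

Measured so far:
compound 1, `COc1cc(/C=C/C(=O)c2cccc(-n3cc(-c4ccc(Cl)cc4)[nH]c3=O)c2)cc(OC)c1OC` — 8880 nM
compound 2, `COc1ccc(-c2cn(-c3cccc(C(=O)/C=C/c4ccc(O)c(OC)c4)c3)c(=O)[nH]2)cc1` — 3960 nM

Both were tested in a functional assay on UACC-62 cells (Homo sapiens) for inhibition; a higher number here means a weaker inhibitor of growth, a lower number a stronger inhibitor of growth. Compound 1 gives 8880 nM, the highest of the two numbers; the nearest is compound 2, whose lower number lies beyond the usual scatter, so compound 1 is the weaker of the pair. Compound 3, `COc1cc(/C=C/C(=O)c2cccc(-n3cc(-c4cc(OC)c(OC)c(OC)c4)[nH]c3=O)c2)cc(OC)c1OC`, has not yet been measured. It arises from compound 1 by one change: 3,4,5-trimethoxyphenyl in place of 4-chlorophenyl on an aromatic carbon. Among the compounds with values here, no measured pair differs by exactly this change, so its effect is not known. Compound 2 carries more methoxy groups than compound 1 and gives the lower number, but that pair differs in several places at once. Still, a move toward a lower number seems likelier than the reverse, and the expected step from compound 1 to compound 3 in this assay is a 2.5-fold lower number from compound 1 to compound 3 (0.40 log units; beyond the scatter). Compound 3 is estimated at 3500 nM, within 900 nM to 13000 nM.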

Compound 3, concentration for 50% growth inhibition: 1870 nM
Compound 3: middle estimate off by 1.9-fold (0.27 log units), on the high side, within the range that was stated.
By their numbers in this assay, from the lowest: compound 3; then compound 2; then compound 1.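

On the aromatic carbon of the five-membered aromatic ring with 2 nitrogen, exchanging 4-chlorophenyl for 3,4,5-trimethoxyphenyl gives a 4.7-fold lower number from compound 1 to compound 3 (0.68 log units; beyond the scatter) in this assay as the read-out. This is the only pair shown that differs in one place, so it gives the first direct sign that the group on this carbon affects growth inhibition, and that the larger group, which counts hydrogen-bond acceptors where 4-chlorophenyl has none, goes with the stronger inhibitor. No measurement shown explains the step, so it stands as an observation.

As far as these compounds go, whether all three methoxy groups are needed for this step remains open. So does whether a phenyl ring carrying an amine or a carboxylic acid on this carbon would shift the number in the same direction.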